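The source may hold more compounds than are shown below. What is called first, only, known or untested is meant among the compounds shown, and "the series" means these compounds.

Measured compounds in a toxicity assay on HEK-293T cells (Homo sapiens) for cytotoxicity, read by MTT assay, with a stated time of 48 h; on this read-out higher numbers stand for weaker inhibition and lower numbers for stronger inhibition:

- compound 1 `C=C1[C@H](O)[C@@H](OC(=O)C(C)(C)C)[C@@H](O)C(C)(C)/C=C/[C@H](C)[C@H](OC(=O)c2ccccc2)[C@@]2(O)C[C@@](C)(O)[C@H](OC(C)=O)[C@@H]2[C@H]1OCC(C)C`: 31700 nM
- compound 2 `C=C1[C@H](O)[C@@H](OC(=O)c2cccc(C)c2)[C@@H](O)C(C)(C)/C=C/[C@H](C)[C@H](OC(=O)c2ccccc2)[C@@]2(O)C[C@@](C)(O)[C@H](OC(C)=O)[C@@H]2[C@H]1OCC(C)C`: 31300 nM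
- compound 3 `C=C1[C@H](OC(C)=O)[C@@H](OC(=O)C(C)(C)C)[C@@H](OC(C)=O)C(C)(C)/C=C/[C@H](C)[C@H](OC(=O)c2ccccc2)[C@@]2(O)C[C@@](C)(O)[C@H](OC(C)=O)[C@@H]2[C@H]1OCC(C)C`: 52100 nM

Compound 1 and compound 2 differ by 3-methylphenyl in place of tert-butyl on a carbonyl carbon, and the step was a 1.0-fold lower number from compound 1 to compound 2 (0.01 log units; within the scatter). Compound 3 shares the same (tert-butyl)carbonyl group as compound 1 but its core is otherwise different; the difference between the two cores is not broken down here. In this assay compound 3 gives 52100 nM, and compound 1 gives 31700 nM, a gap within the scatter.

Compound 4 `C=C1[C@H](OC(C)=O)[C@@H](OC(=O)c2cccc(C)c2)[C@@H](OC(C)=O)C(C)(C)/C=C/[C@H](C)[C@H](OC(=O)c2ccccc2)[C@@]2(O)C[C@@](C)(O)[C@H](OC(C)=O)[C@@H]2[C@H]1OCC(C)C` is not yet measured. It differs from compound 3 by 3-methylphenyl in place of tert-butyl on a carbonyl carbon, the same change that was made from compound 1 to compound 2. Because that earlier step was a 1.0-fold lower number from compound 1 to compound 2 (0.01 log units; within the scatter), the expected step from compound 3 to compound 4 in this assay is a 1.0-fold lower number from compound 3 to compound 4 (0.00 log units; within the scatter). For compound 4 the expected value in this assay is 52000 nM, likely within 26000 nM to 105000 nM.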

Compound 4, half-maximal inhibitory concentration: 4110 nM
Compound 4: the middle estimate sits 13-fold (1.10 log units) above what was measured; the measured number lies below the stated range.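

In this assay, 3-methylphenyl in place of tert-butyl on a carbonyl carbon gives a 13-fold lower number from compound 3 to compound 4 (1.10 log units; beyond the scatter), so the near-silent step seen on the core of compound 1 does not carry over to the core of compound 3: the same change on two cores in this assay, a 1.0-fold lower number (0.01 log units; within the scatter) from compound 1 to compound 2 and a 13-fold lower number (1.10 log units; beyond the scatter) from compound 3 to compound 4, 13-fold (1.10 log units) apart, beyond the scatter of two such steps

The size of this step therefore depends on the core in these two pairs, and a step read on one core is a poor guide to the other. This does not show which part of the difference between the two cores is responsible, and two pairs set no rule for the wider series.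

Open, as far as these compounds go, is how a longer chain, or a phenyl carrying an amine or a carboxylic acid, would behave on that carbonyl on each core. Also open, from the compounds shown here alone, is whether such groups would repeat the core dependence seen with 3-methylphenyl.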